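The compounds below may be only part of what the source reports. "The series", "measured", "known", "first", "only" and "open" are said of these compounds alone.

Compound 1 `C[C@@H]1CCCN1c1c(C#N)c2c(N)nc(Nc3cnn(C)c3)cc2n1C`: 794 nM
Compound 2 `C[C@@H]1CCCN1c1c(C#N)c2c(N)nc(Nc3ccn(C)n3)cc2n1C`: 13 nM

Both compounds were tested in an assay on isolated protein for binding affinity to Leucine-rich repeat serine/threonine-protein kinase 2 variant G2019S (Homo sapiens), read by TR-FRET and LanthaScreen, with a stated time of 2 h; on this read-out higher numbers stand for weaker inhibition and lower numbers for stronger inhibition. Compound 2 holds the lowest of the two numbers. Its nearest neighbour is compound 1, which in this assay gives 794 nM. Among the compounds with values here, the one measured step, a 61-fold lower number from compound 1 to compound 2 (1.79 log units; beyond the scatter), came from shifting the attachment point of the methylpyrazole ring, so that ring is the only part of the shared core for which anything is known here.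

Compound 3 `C[C@@H]1CCCN1c1c(C#N)c2c(N)nccc2n1C` goes further in the same region: the change is hydrogen in place of (1-methyl-1H-pyrazol-3-yl)amino on an aromatic carbon. Within the data shown here, no measured step deletes this group; the only step that bears on it is a 61-fold lower number from compound 1 to compound 2 (1.79 log units; beyond the scatter), which shows that a mere change within the group already moved the number a long way. Removing the group altogether is expected to cost more than rearranging it, so a large step towards a higher number is expected, a 460-fold higher number from compound 2 to compound 3 (2.66 log units; beyond the scatter). For compound 3 the value in this assay is estimated at 6000 nM, within a range from 800 nM to 40000 nM.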

Compound 3, inhibition constant: 2 nM
Compound 3: the middle estimate sits 3000-fold (3.48 log units) above what was measured; measured number below the stated range.
By their numbers in this assay, from the lowest: compound 3; then compound 2; then compound 1.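

In this assay the (1-methyl-1H-pyrazol-3-yl)amino group proves unnecessary for a low number at this aromatic carbon, next to the ring nitrogen: replacing it with hydrogen gives a 6.5-fold lower number from compound 2 to compound 3 (0.81 log units; beyond the scatter) and removes a whole ring-bearing substituent without any loss. The same replacement of the 4-yl isomer gives a 400-fold lower number from compound 1 to compound 3 (2.60 log units; beyond the scatter), so both substituents shown here carry higher numbers than plain hydrogen, and the earlier gain from moving the attachment point now reads as a smaller penalty rather than as an improvement on the unsubstituted compound. No supporting measurement is available to explain why the smaller compound gives the lowest number of the three.

From the compounds shown here alone, it remains open whether a small group on this carbon, such as a methyl, a fluorine or a plain amino group, would give a number lower or higher than hydrogen does. Also open, going by these compounds, is how the three compounds would rank on the unmutated kinase, since the numbers here cover only the G2019S variant.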